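This account rests on a few compounds, and the source may have more. Where it says the series, first, only, none or still open, it means among the compounds named here.

Three compounds share one core and differ only in a single group on an aromatic carbon of the fused ring system. Compound 1 `CC/C(=C(/c1ccc(/C=C/C(=O)O)cc1)c1ccc2[nH]ncc2c1C)c1ccccc1` carries a methyl there, and in a functional assay on MCF7 cells (Homo sapiens) for cytotoxicity, read by CellTiter-Glo, with a stated time of 5 days (on this read-out higher numbers stand for weaker inhibition and lower numbers for stronger inhibition), compound 1 gives 50 nM. Compound 2 `CC/C(=C(/c1ccc(/C=C/C(=O)O)cc1)c1ccc2[nH]ncc2c1F)c1ccccc1` carries a fluoro, and in this assay compound 2 gives 3 nM. Compound 3 `CC/C(=C(/c1ccc(/C=C/C(=O)O)cc1)c1ccc2[nH]ncc2c1Cl)c1ccccc1` carries a chloro, and in this assay compound 3 gives 1.6 nM, the lowest of the three numbers; its step of a 1.9-fold lower number from compound 2 to compound 3 (0.27 log units; within the scatter) lies within the scatter, whereas a 31-fold lower number from compound 1 to compound 3 (1.49 log units; beyond the scatter) and, for comparison, a 17-fold lower number from compound 1 to compound 2 (1.22 log units; beyond the scatter) are large.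

Compound 4 `CC/C(=C(/c1ccc(/C=C/C(=O)O)cc1)c1ccc2[nH]ncc2c1OC)c1ccccc1` is the next variation: methoxy in place of chloro on an aromatic carbon. Among the compounds with values here, no measured step involves a methoxy, so the only guide is that a chloro or a fluoro in place of a methyl lowered the number strongly. A methoxy is neither a halogen nor a methyl, so compound 4 is expected to land between those outcomes, with a step of a 9.4-fold higher number from compound 3 to compound 4 (0.97 log units; beyond the scatter) toward a higher number in this assay. The estimate for compound 4 is 15 nM, with a range from 4 nM to 60 nM.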

Compound 4, half-maximal inhibitory concentration: 55 nM
For compound 4 the middle estimate is 3.7-fold (0.56 log units) below the measured one; the range from low to high includes it.
By their numbers in this assay, from the lowest: compounds 3 and 2 (each within the scatter of the next); then compounds 1 and 4 (each within the scatter of the next).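

In this assay, a methoxy at this position cannot be told apart from a methyl, with a 1.1-fold higher number from compound 1 to compound 4 (0.04 log units; within the scatter) as the step between them. The same methoxy differs widely from both halogens, with a 34-fold higher number from compound 3 to compound 4 (1.54 log units; beyond the scatter) and an 18-fold higher number from compound 2 to compound 4 (1.26 log units; beyond the scatter) as the steps, so the four groups fall into two pairs: fluoro and chloro give low numbers, while methyl and methoxy give higher numbers. Nothing measured here bears on why the groups divide in this way.

The compounds shown leave open whether a bromo would join the halogen pair, and where a hydroxyl or an amine at this position would fall. They also leave open whether a longer chain, such as an ethoxy, would stay level with the methoxy or move further from the halogens.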